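Lengthening the Alkyl Chain: What to Expect for Compound 4

A few compounds are considered here, and "the series" means these few. Any claim that something is new, unique, unknown or untested is made for them only; others in the source may bear on it.

Of the compounds shown here, three have been measured in a functional assay on MDA-MB-231 cells (Homo sapiens) for antiproliferative activity, with a stated time of 4 days; on this read-out lower numbers stand for stronger inhibition and higher numbers for weaker inhibition. Compound 1 `CCCc1ccc2[nH]c(-c3ccc(OC)cc3)c(C=C(C#N)C#N)c2c1` gives 83 nM. Compound 2 `CCCCc1ccc2[nH]c(-c3ccc(OC)cc3)c(C=C(C#N)C#N)c2c1`, which carries a longer chain, gives 26 nM. Compound 3 `CCCCCc1ccc2[nH]c(-c3ccc(C(F)(F)F)cc3)c(C=C(C#N)C#N)c2c1`, built on a different core, gives 78 nM; the difference between the core of compound 3 and the core of compound 1 is not broken down here, and the two values sit close together.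

The one step that has been measured, a 3.2-fold lower number from compound 1 to compound 2 (0.50 log units; beyond the scatter), arises from the change methyl in place of hydrogen on a saturated chain carbon, three bonds along the chain from an aromatic carbon

Compound 4 `CCCCCCc1ccc2[nH]c(-c3ccc(C(F)(F)F)cc3)c(C=C(C#N)C#N)c2c1` has not yet been measured in this assay. Its change from compound 3 is methyl in place of hydrogen on a saturated chain carbon, five bonds along the chain from an aromatic carbon

This is the same kind of change as that from compound 1 to compound 2, but not the same: the added methyl sits five bonds along the chain from an aromatic carbon in compound 4, against three bonds in compound 2, and the cores differ as well. On the strength of the measured step from compound 1 to compound 2, a gain of roughly comparable size is expected, though with some caution, since the two places and cores differ. For compound 4 the expected step is a 2.0-fold lower number from compound 3 to compound 4 (0.29 log units; within the scatter). Compound 4 is thus estimated at 40 nM in this assay, with a likely range from 15 nM to 120 nM.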

Compound 4, half-maximal inhibitory concentration: 150 nM
The estimate for compound 4 lay 3.8-fold (0.57 log units) below the measured number, outside the stated range (above it).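

In this assay the added methyl now gives a 1.9-fold higher number from compound 3 to compound 4 (0.28 log units; within the scatter), a step that stays inside the usual scatter, so the gain seen on the core of compound 1 does not reappear here. Set side by side, the two steps differ: the same change on two cores in this assay, a 3.2-fold lower number (0.50 log units; beyond the scatter) from compound 1 to compound 2 and a 1.9-fold higher number (0.28 log units; within the scatter) from compound 3 to compound 4, 6.1-fold (0.79 log units) apart, beyond the scatter of two such steps. This shows that the change cannot be carried as a fixed gain from one core to the other in this series, but it does not show what separates the two cases: the pairs differ both in the core and in the place of the methyl, three bonds against five bonds along the chain from an aromatic carbon, and one pair on each side cannot pull these apart.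

The compounds shown leave open whether a longer chain on the core of compound 1 would keep the gain, and whether the step from propyl to butyl on the core of compound 3 would show it, which would separate place from core. They also leave open how a still longer chain, or an amine or a carboxylic acid in place of the added methyl, would read on either core.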